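The compounds below may be only part of what the source reports. "The series", "measured", "known", "first", "only" and "open" are said of these compounds alone.

Among the compounds with values here, compound 1 `COc1ccc(S(=O)(=O)c2cnc3cc(F)ccc3c2N2CCC(C)CC2)cc1` sits at the top of the two numbers so far: in an assay on isolated protein for displacement of a labelled ligand from metabotropic glutamate receptor 5 (Homo sapiens), with a stated time of 60 min, tested at 1 uM (a lower number here means less inhibition, a higher number more inhibition at the concentration tested (going by the name of the read-out)), compound 1 gives 90%. Compound 2 `COc1ccc(S(=O)(=O)c2cnc3cc(Cl)ccc3c2N2CCC(C)CC2)cc1` gives 79%, and the step of a number 11 percentage points lower from compound 1 to compound 2 (beyond the scatter) came with chloro in place of fluoro on an aromatic carbon. Compound 3 `CC1CCN(c2c(S(=O)(=O)c3cc(Cl)cc(Cl)c3)cnc3cc(F)ccc23)CC1` differs from compound 1 by 3,5-dichlorophenyl in place of 4-methoxyphenyl on a sulfonyl sulfur. Within the data shown here, no measured step touches the group on the sulfonyl sulfur, so the one known step gives only a sense that single swaps moved the read-out modestly. Compound 3 is therefore expected to stay high, with a step of a number 10 percentage points lower from compound 1 to compound 3 (within the scatter), and an estimated value of 80% between 55% and 95%.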

Compound 3, a percentage reported as inhibition, at one concentration (the size of the read-out at that concentration, not a potency): 87%
For compound 3 the middle estimate is 7 percentage points below the measured one, within the range that was stated.
By their numbers in this assay, from the lowest: compounds 2, 3 and 1 (each within the scatter of the next, the first and the last beyond it).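

In this assay, 3,5-dichlorophenyl in place of 4-methoxyphenyl on the sulfonyl sulfur gives a number 3 percentage points lower from compound 1 to compound 3 (within the scatter). The aromatic ring on the sulfonyl sulfur can therefore carry two chlorines instead of a methoxy group, losing the oxygen acceptor, with no change beyond the scatter for this pair. No measurement here explains why the number stays level.

Still open, on these data alone, is whether the sulfonyl sulfur accepts something other than a substituted phenyl, such as a methyl group or a chain ending in an amine. Also open, as far as these compounds go, is how 3,5-dichlorophenyl behaves with chloro in place of fluoro on the core.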